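The compounds below may be only part of what the source reports. "The series", "measured", "known", "first", "only" and "open" are said of these compounds alone.

Compound 1 `Cc1nnc(SCC(=O)N/N=c2/scc(-c3ccc(C#N)cc3)n2-c2ccccc2)s1`: in an ADME assay on NIH3T3 cells (Mus musculus) for cytotoxicity, read by MTT assay, with a stated time of 24 h (a lower number here means a stronger inhibitor, a higher number a weaker inhibitor), compound 1 gives < 3.9 ug/mL, a limit of the assay and not a number.
Compound 2 `Cn1cnnc1SCC(=O)N/N=c1/scc(-c2ccc(Br)cc2)n1-c1ccccc1`: compound 2 gives 58.3 ug/mL.
Compound 3 `COc1ccc(-c2cs/c(=N/NC(=O)CSc3nncn3C)n2-c2ccccc2)cc1`: compound 3 gives 167 ug/mL.

For the measured compounds named here, compound 3 stands highest of the two numbers; the only measured step, a 2.9-fold higher number from compound 2 to compound 3 (0.46 log units; beyond the scatter), carries methoxy in place of bromo and lies beyond the scatter. Compound 4 `COc1ccc(-c2cs/c(=N/NC(=O)CSc3nnc(C)s3)n2-c2ccccc2)cc1` differs from compound 3 by 5-methyl-1,3,4-thiadiazol-2-yl in place of 4-methyl-4H-1,2,4-triazol-3-yl on a sulfur. Going by the values given here, no measured step bears on that change. Compound 1 also carries the 5-methyl-1,3,4-thiadiazol-2-yl group, yet it differs from compound 3 in a second place as well, and its result is only (the limit of < 3.9 ug/mL in this assay, at which 1 of the 3 values shown sits). The step is therefore expected to be modest, a 1.9-fold lower number from compound 3 to compound 4 (0.27 log units; within the scatter), toward a lower number. Compound 4 is estimated at 90 ug/mL, between 25 ug/mL and 300 ug/mL.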

Compound 4, half-maximal inhibitory concentration: 300 ug/mL
Compound 4: the middle estimate sits 3.3-fold (0.52 log units) below what was measured, and the stated range covers the measured number.
By their numbers in this assay, from the lowest: compound 2; then compounds 3 and 4 (each within the scatter of the next). At a limit, below all of these: compound 1.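

In this assay, the step with 5-methyl-1,3,4-thiadiazol-2-yl in place of 4-methyl-4H-1,2,4-triazol-3-yl on the sulfur can now be read directly as a 1.8-fold higher number from compound 3 to compound 4 (0.25 log units; within the scatter) and does not separate the two methoxy compounds. With 5-methyl-1,3,4-thiadiazol-2-yl held constant, methoxy in place of cyano gives an at least 76-fold higher number from compound 1 to compound 4 (1.88 log units; beyond the scatter) and so marks the aromatic carbon as the place of the large difference. Compound 1 stands at a limit and not a number: the limit of < 3.9 ug/mL in this assay, at which 1 of the 4 values shown sits. Still open, on these data alone, is how an amine or a carboxylic acid on that aromatic carbon would read, and whether cyano keeps its effect alongside 4-methyl-4H-1,2,4-triazol-3-yl.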